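The compounds below may be only part of what the source reports. "The series", "measured", "known", "first", "only" and "open" are said of these compounds alone.

Compound 1 `COc1cc(-c2nccn2CC(C)C)cc(OC)c1OC` sits at the assay limit in a functional assay on MDA-MB-231 cells (Homo sapiens) for antiproliferative activity, read by MTT assay, with a stated time of 72 h; on this read-out higher numbers stand for weaker inhibition and lower numbers for stronger inhibition: compound 1 gives > 100000 nM, which is a limit and not a number, as the limit of > 100000 nM in this assay, at which 1 of the 2 values shown sits, records. Compound 2 `COc1cc(-c2nccn2-c2ccc3[nH]ccc3c2)cc(OC)c1OC` gives 4300 nM in this assay. Compound 3 `COc1ccc(-n2ccnc2-c2cc(OC)c(OC)c(OC)c2)cc1` carries the change (4-methoxyphenyl in place of isobutyl on an aromatic nitrogen). Among the measured compounds shown here, no step between measured compounds is available, so the size of this change in this assay is open; the expectation is a move toward stronger inhibition well beyond the scatter, since compound 2 reaches 4300 nM in this assay. Compound 3 is expected at 2000 nM, with a range of 300 nM to 15000 nM. The expected step is an at least 50-fold lower number from compound 1 to compound 3 (1.69 log units; beyond the scatter).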

Compound 3, half-maximal inhibitory concentration: 2700 nM
The estimate for compound 3 lay 1.4-fold (0.13 log units) below the measured number; measured number inside the range.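

In this assay, 4-methoxyphenyl in place of isobutyl on the aromatic nitrogen gives an at least 37-fold lower number from compound 1 to compound 3 (1.56 log units; beyond the scatter) and thus shows that activity at this position can be gained with a single aromatic ring carrying one methoxy group. Compound 1 at > 100000 nM is a limit and not a number, and the full size of the step stays unread. As far as these compounds go, what a plain phenyl, a benzyl or a pyridyl group would give on this nitrogen remains open, as does the contribution of the methoxy group itself.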